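A few compounds are considered here, and "the series" means these few. Any claim that something is new, unique, unknown or untested is made for them only; others in the source may bear on it.

Measured compounds:
compound 1 `CCN(CC)CCCOc1cc2ncnc(Nc3nc4ccc(C(=O)Nc5c(C)cccc5C)cc4s3)c2cc1OC` — > 100000 nM
compound 2 `COc1cc2c(Nc3nc4ccc(C(=O)Nc5c(C)cccc5Cl)cc4s3)ncnc2cc1OCCCN1CCC(C)CC1` — 9700 nM
compound 3 `CCN(CC)CCCOc1cc2ncnc(Nc3nc4ccc(C(=O)Nc5c(C)cccc5Cl)cc4s3)c2cc1OC` — 10600 nM

The three compounds share a core and were tested in a functional assay on A549 cells (Homo sapiens) for cytotoxicity, read by WST assay, with a stated time of 72 h; on this read-out higher numbers stand for weaker inhibition and lower numbers for stronger inhibition. Compound 1 gives only a limit there, > 100000 nM, so no number is known for it; it sits at the limit of > 100000 nM in this assay, at which 1 of the 3 values shown sits. Compound 3 gives 10600 nM and compound 2 gives 9700 nM. Between them the change a 1.1-fold higher number from compound 2 to compound 3 (0.04 log units; within the scatter) shows that swapping the amine on the chain left the read-out where it was, while an at least 9.4-fold lower number from compound 1 to compound 3 (0.97 log units; beyond the scatter) is the one change among these three that moved the read-out beyond the scatter.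

Compound 4 `COc1cc2c(Nc3nc4ccc(C(=O)Nc5c(C)cccc5C)cc4s3)ncnc2cc1OCCCN1CCCCC1` is not yet measured. It differs from compound 1 by piperidin-1-yl in place of diethylamino on a saturated chain carbon, three bonds along the chain from an oxygen on an aromatic ring. Among the compounds with values here, the step that bears on this change is the one between compound 2 and compound 3, an exchange of the same kind at the same place, and it was within the scatter. Within the data shown here, compound 4 keeps the methyl of compound 1 rather than the chloro of compound 3, so the one step that did move the read-out does not apply. The step from compound 1 to compound 4 is therefore expected to be a number no higher from compound 1 to compound 4 (the limit leaves the size open), none beyond the scatter, and compound 4 is expected to lie at about 100000 nM (from 30000 nM to 300000 nM) in this assay, most likely again reported only as a limit.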

Compound 4, half-maximal inhibitory concentration: > 100000 nM
Compound 4: a limit, no number; the forecaster's own chance of this, stated with the estimate: 70%; the middle value lies on the limit itself.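

Compound 4, like compound 1, gives only a limit in this assay, so no step can be read from compound 1 to compound 4: the limit of > 100000 nM in this assay, at which 2 of the 4 values shown sit. The compounds shown leave open whether piperidin-1-yl in place of diethylamino changes the read-out at all while the methyl of compound 1 is kept.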